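Swapping the halogen on the benzylidene ring

The compounds below may be only part of what the source reports. "The series", "measured", "known", "first", "only" and "open" are said of these compounds alone.

Compound 1 `C=CCn1c(=O)/c(=C\c2cccc(Cl)c2)[nH]c(=O)/c1=C\c1ccccc1OC` — 5200 nM
Compound 2 `COc1ccccc1/C=c1/[nH]c(=O)/c(=C\c2cccc(Cl)c2Cl)[nH]c1=O` — "not active" (no number reported)
Compound 3 `C=CCn1c(=O)/c(=C\c2cccc(F)c2)[nH]c(=O)/c1=C\c1ccccc1OC` — 13700 nM

In a functional assay on MCF7 cells (Homo sapiens) for cytotoxicity, read by CCK-8 assay, with a stated time of 72 h (a lower number here means a stronger inhibitor, a higher number a weaker inhibitor), compound 3 holds the highest of the two reported numbers; its nearest neighbour is compound 1, which gives 5200 nM. Compound 2, built on a different core, is reported as "not active" (no number reported) without a number.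

Compound 4 `C=CCn1c(=O)/c(=C\c2ccccc2Cl)[nH]c(=O)/c1=C\c1ccccc1OC` carries 2-chlorophenyl in place of 3-fluorophenyl on a double-bonded chain carbon bound to an aromatic carbon. Within the data shown here, the one step that bears on this is a 2.6-fold higher number from compound 1 to compound 3 (0.42 log units; beyond the scatter), where putting fluorine in for chlorine raised the number. Among the measured compounds shown here, compound 4 reverses that exchange, yet the chlorine now sits as 2-chlorophenyl rather than the 3-fluorophenyl of compound 3, and no measured step covers that shift. A modest return toward compound 1 is therefore expected, a 2.5-fold lower number from compound 3 to compound 4 (0.40 log units; beyond the scatter). Compound 4 is estimated at 5500 nM, with a range from 2000 nM to 16000 nM.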

Compound 4, half-maximal inhibitory concentration: 4700 nM
The estimate for compound 4 lay 1.2-fold (0.07 log units) above the measured number; the range from low to high includes it.
By their numbers in this assay, from the lowest: compounds 4 and 1 (each within the scatter of the next); then compound 3.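

In this assay, the chlorine can stand as 2-chlorophenyl or as 3-chlorophenyl on this double-bonded chain carbon, and the two compounds cannot be told apart (a 1.1-fold lower number from compound 1 to compound 4 (0.04 log units; within the scatter)). The 3-fluorophenyl compound stands clear of the new one (a 2.9-fold lower number from compound 3 to compound 4 (0.46 log units; beyond the scatter)), so both chlorophenyl compounds now give lower numbers than the fluorine compound. Nothing available explains this difference. On these data alone, whether a ring carrying an amine or a carboxylic acid at this place would hold the same level remains open. So does whether 2-fluorophenyl would match 2-chlorophenyl.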